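This account rests on a few compounds, and the source may have more. Where it says the series, first, only, none or still open, it means among the compounds named here.

Measured compounds:
compound 1, `CCc1nc(NC(CC)CC)c(F)nc1-c1ccc(Cl)cc1Cl`, 167 nM
compound 2, `CCc1nc(-c2ccc(C)cc2OC)c(CC)nc1NC(CC)CC`, 23.7 nM

In an assay on IMR-32 cells for displacement of a labelled ligand from corticotropin-releasing factor receptor 1 (Homo sapiens), read by scintillation counting, with a stated time of 2 h (on this read-out higher numbers stand for weaker inhibition and lower numbers for stronger inhibition), compound 1 gives the higher of the two numbers; compound 2 gives a lower number, a gap beyond the usual scatter. Compound 3, `CCc1nc(NC(CC)CC)cnc1-c1ccc(Cl)cc1Cl`, differs from compound 1 in one place: hydrogen in place of fluoro on an aromatic carbon. Among the measured compounds shown here, no pair of measured compounds differing in one place is available, so the size of this change rests on no measured step. Compound 3 is expected to stay close to compound 1, with an estimated step of a 1.5-fold higher number from compound 1 to compound 3 (0.18 log units; within the scatter) toward a somewhat weaker value, possibly just beyond the scatter. In this assay the estimated value of compound 3 is 250 nM, with a range from 80 nM to 800 nM.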

Compound 3, inhibition constant: 545 nM
Estimate against measurement, compound 3: 2.2-fold (0.34 log units) below; low and high end bracket the measured number.
By their numbers in this assay, from the lowest: compound 2; then compound 1; then compound 3.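

In this assay, the place next to the ring nitrogen and ortho to the (pentan-3-yl)amino group proves sensitive to a change of a single atom: hydrogen in place of fluoro gives a 3.3-fold higher number from compound 1 to compound 3 (0.51 log units; beyond the scatter). Among the compounds shown here, this is the first measured step at this position, and it shows that the fluoro compound gives the stronger inhibition of this pair. Nothing in the data at hand accounts for this step.

Going by these compounds, whether a chloro, methyl or methoxy group here would match fluoro or hydrogen remains open. Also open, on these data alone, is whether the step would keep its size with a cyclopropylmethylamino group in place of the (pentan-3-yl)amino group.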